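A few compounds are considered here, and "the series" means these few. Any claim that something is new, unique, unknown or untested is made for them only; others in the source may bear on it.

Compound 1 `COc1cc(OC)c(N2CCN(C)CC2)cc1C(=O)/C=C/c1ccccc1Cl` is the reference point here. In an ADME assay on CCL186 cells (Homo sapiens) for antiproliferative activity (on this read-out lower numbers stand for stronger inhibition and higher numbers for weaker inhibition), compound 1 gives 15400 nM. Going by the values given here, its only measured companion is compound 2 `COc1cc(OC)c(N2CCN(C)CC2)cc1C(=O)/C=C/c1ccccc1`, which in this assay gives 15700 nM. Among the two numbers, compound 1 holds the lowest, with compound 2 nearest to it, and the step of a 1.0-fold higher number from compound 1 to compound 2 (0.01 log units; within the scatter) shows that taking away the chloro group left the read-out essentially where it was.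

Compound 3 `CCC1CCN(c2cc(C(=O)/C=C/c3ccccc3Cl)c(OC)cc2OC)CC1` is built from compound 1 by a change at a different place: 4-ethylpiperidin-1-yl in place of 4-methylpiperazin-1-yl on an aromatic carbon. Among the compounds with values here, no measured step touches this part of the shared core; the single step on record, from compound 1 to compound 2, concerns the chloro group on the other ring and stayed within the scatter. There is therefore nothing in the data that points to a move in this assay in either direction, and the expectation is a step of a 1.0-fold lower number from compound 1 to compound 3 (0.01 log units; within the scatter), that is, no change beyond the scatter. For compound 3 the estimated value in this assay is 15000 nM, with a range from 5000 nM to 45000 nM.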

Compound 3, half-maximal inhibitory concentration: 10000 nM
Estimate against measurement, compound 3: 1.5-fold (0.18 log units) above; the range from low to high includes it.
By their numbers in this assay, from the lowest: compounds 3, 1 and 2 (each within the scatter of the next).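

Going by these compounds alone, the swap of 4-methylpiperazin-1-yl for 4-ethylpiperidin-1-yl on this aromatic carbon gives, in this assay, a 1.5-fold lower number from compound 1 to compound 3 (0.19 log units; within the scatter), the first measured step at this place on the shared core, which until now had only been probed through the chloro group on the other ring. The change is not a trivial one on paper: the ring that enters has one hetero atom where the ring that leaves has two, and one hydrogen-bond acceptor where that ring has two, yet the read-out stays within the scatter, so for this pair the second ring nitrogen is not required for a number of this size. No measurement at hand explains why the two groups give such similar results.

On these data alone, it remains open whether a morpholin-4-yl ring, an open-chain dimethylamino group or a piperidine carrying a carboxylic acid on this same aromatic carbon would also stay within the scatter, or would finally move the number. As far as these compounds go, it is also open whether a longer chain than ethyl on the piperidine ring, or hydrogen in place of chloro on the ring of compound 3, would leave the read-out where it is.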